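Smaller Aromatic Substituent on a Spirocyclic Thiazoline Core

The compounds below may be only part of what the source reports. "The series", "measured", "known", "first", "only" and "open" are said of these compounds alone.

Measured so far:
compound 1, `CC(C)c1ccc(NC2=NCCC3(CCCCC3)S2)cc1`, 15.7 10^-6 cm/s
compound 2, `O=C(NC1=NCCC2(CCCCC2)S1)c1ccccc1`, 3.18 10^-6 cm/s
compound 3, `Cc1cccc(C(C)C)c1NC1=NCCC2(CCCCC2)S1`, 9.04 10^-6 cm/s

Of the compounds shown here, three sharing the same core have been measured in a physicochemical assay for permeability; on this read-out lower numbers stand for lower permeability and higher numbers for higher permeability. Compound 1 gives the highest of the three numbers in this assay. Compound 3 comes nearest, with a number lower by a margin that lies within the scatter, so the two cannot be ranked against each other. Compound 2 sits furthest away, and its lower number lies beyond the scatter.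

Compound 4, `Cc1ccc(NC2=NCCC3(CCCCC3)S2)cc1`, has not yet been measured in this assay. It differs from compound 1 in one place: methyl in place of isopropyl on an aromatic carbon. Methyl in place of isopropyl on an aromatic carbon removes two carbons from the group that sits on the aromatic ring, with no change in donors, acceptors or charge.

Among the compounds with values here, no measured pair here isolates this exact change, so the expectation rests on what the three measured compounds show. Because compound 3, with a smaller alkyl group on the ring, gives 9.04 10^-6 cm/s, a modest downward step is expected, one that may well stay within the scatter. The estimated step is a 1.6-fold lower number from compound 1 to compound 4 (0.20 log units; within the scatter). Compound 4 is expected to give 10 10^-6 cm/s, within a range from 5 10^-6 cm/s to 20 10^-6 cm/s.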

Compound 4, apparent permeability: 5.67 10^-6 cm/s
Estimate against measurement, compound 4: 1.8-fold (0.25 log units) above; the measured number falls inside the stated range.
By their numbers in this assay, from the lowest: compounds 2, 4, 3 and 1 (each within the scatter of the next, the first and the last beyond it).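

Replacing isopropyl with methyl on this aromatic carbon, para to a large group, gives a 2.8-fold lower number from compound 1 to compound 4 (0.44 log units; beyond the scatter) in this assay. Within the data shown here, this is the first single change on the shared core that can be read directly, since no two earlier compounds differed in only one place. It shows that the number at this position shifts by more than the usual scatter when only the size of the alkyl group changes, with hydrogen-bond donors, acceptors and net charge all the same, but nothing available explains the shift.

On these data alone, with only these two groups compared here, it remains open whether the number would follow alkyl size through ethyl or a longer chain such as butyl. As far as these compounds go, what an amine or a carboxylic acid at this same place would give in this assay also remains open.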